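The source may report more compounds than this note shows. Statements on the series, on what has been measured and on what is new or still open speak of the compounds shown alone.

Measured so far in a functional assay on MGC-803 cells (Homo sapiens) for antiproliferative activity, read by CCK-8 assay, with a stated time of 72 h, tested at 2 uM; a higher number here means a stronger effect of the compound at the concentration tested, a lower number a weaker effect:
compound 1 `Nc1ccccc1NC(=O)c1ccc(CSC(=S)N2CCN(Cc3ccccn3)CC2)cc1`: 23.4%
compound 2 `Nc1ccccc1NC(=O)c1ccc(CSC(=S)N2CCc3ccccc32)cc1`: 44%
compound 3 `Nc1ccccc1NC(=O)c1ccc(CSC(=S)N2CCCc3ccccc32)cc1`: 38.5%

Compound 1 stands lowest of the three numbers in this assay; compound 3 lies beyond the scatter above it, and compound 2 further still. Within the data shown here, the one step between neighbours that differ in a single place, a number 5.5 percentage points lower from compound 2 to compound 3 (within the scatter), concerns the ring on the thiocarbonyl carbon and is within the scatter.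

Compound 4 `Nc1ccccc1NC(=O)c1ccc(CSC(=S)N2CCN(c3ccccc3F)CC2)cc1` is not yet measured. It differs from compound 1 in one place: 2-fluorophenyl in place of (pyridin-2-yl)methyl on an amine nitrogen in a ring. Among the measured compounds shown here, no measured step touches this part of the shared core; the only measured step changes the group on the thiocarbonyl carbon and leaves the amine nitrogen in the ring untouched, so it gives no guide to direction or size here. For the measured compounds named here, the values of compound 2 and compound 3 show only that the shared core can reach the higher numbers seen there when the thiocarbonyl-bound ring is varied. With nothing pointing either way, the step in this assay is expected to be none beyond the scatter: a number 2.6 percentage points higher from compound 1 to compound 4 (within the scatter). Compound 4 is therefore estimated at 26%, with a range from 10% to 45%, kept wide for lack of any bearing step.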

Compound 4, a percentage reported as inhibition, at one concentration (the size of the read-out at that concentration, not a potency): 33.7%
Estimate against measurement, compound 4: 7.7 percentage points below, and the stated range covers the measured number.
By their numbers in this assay, from the lowest: compound 1; then compounds 4, 3 and 2 (each within the scatter of the next, the first and the last beyond it).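

In this assay, among these compounds, the group on the amine nitrogen in the ring proves able to move the read-out: 2-fluorophenyl in place of (pyridin-2-yl)methyl gives a number 10.3 percentage points higher from compound 1 to compound 4 (beyond the scatter) and this modest step is the first seen at this place. The two groups have the same heavy-atom count, and each carries one six-membered aromatic ring, yet they differ at once in the ring nitrogen, the fluorine, the methyl link and the hydrogen-bond acceptor count, so this single step cannot assign the change to any one of these features. Nothing at hand accounts for the step.

Still open, on these data alone, is which of these differences matters, and a plain phenyl, a benzyl or a pyridin-2-yl set directly on the same nitrogen would begin to separate them. Also unresolved is whether the step holds with a chlorine or a methoxy group in place of the fluorine, and whether a small alkyl group such as methyl on this nitrogen stays nearer compound 1 or compound 4.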